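From Compound 1 to Compound 4: an Expected Outcome

This account rests on a few compounds, and the source may have more. Where it says the series, first, only, none or still open, it means among the compounds named here.

Compound 1 `C/C(=C\CC/C(C)=C/CC[C@@H]1[C@@]2(C)CCC(=O)C(C)(C)[C@H]2CC[C@@]1(C)O)CC/C=C(\C)C(=O)OCc1cn(-c2ccccc2C(F)(F)F)nn1` belongs to a set of three analogues that share one core and differ only in the group carried on an aromatic nitrogen. In a functional assay on DU-145 cells (Homo sapiens) for antiproliferative activity, read by MTT assay, with a stated time of 48 h (a higher number here means a weaker inhibitor, a lower number a stronger inhibitor), compound 1 gives > 150000 nM, which is a limit of the assay rather than a number. Compound 2 `C/C(=C\CC/C(C)=C/CC[C@@H]1[C@@]2(C)CCC(=O)C(C)(C)[C@H]2CC[C@@]1(C)O)CC/C=C(\C)C(=O)OCc1cn(-c2cccc(Br)c2)nn1` carries 3-bromophenyl in that place; in this assay compound 2 gives > 150000 nM, again a limit. Compound 3 `C/C(=C\CC/C(C)=C/CC[C@@H]1[C@@]2(C)CCC(=O)C(C)(C)[C@H]2CC[C@@]1(C)O)CC/C=C(\C)C(=O)OCc1cn(-c2ccccc2)nn1` carries an unsubstituted phenyl, and in this assay compound 3 gives 95500 nM. The step of an at least 1.5-fold lower number from compound 1 to compound 3 (0.19 log units; that floor lies within the scatter) and the step of an at least 1.5-fold lower number from compound 2 to compound 3 (0.19 log units; that floor lies within the scatter) point the same way, though each floor lies within the scatter, while the step that the two limits leave unreadable from compound 1 to compound 2 cannot be read between two limits. Compound 1 thus stands at the limit, as the limit of > 150000 nM in this assay, at which 2 of the 3 values shown sit, records, with only compound 3 yielding a number.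

Compound 4 `C/C(=C\CC/C(C)=C/CC[C@@H]1[C@@]2(C)CCC(=O)C(C)(C)[C@H]2CC[C@@]1(C)O)CC/C=C(\C)C(=O)OCc1cn(-c2ccc(C)cc2)nn1` differs from compound 1 as follows: 4-methylphenyl in place of 2-(trifluoromethyl)phenyl on an aromatic nitrogen. The steps of an at least 1.5-fold lower number from compound 1 to compound 3 (0.19 log units; that floor lies within the scatter) and an at least 1.5-fold lower number from compound 2 to compound 3 (0.19 log units; that floor lies within the scatter) bear on this change, since both remove a substituent from the phenyl and reach a readable number, whereas compound 4 keeps a methyl on the phenyl. Compound 4 is therefore expected to sit near compound 3, and is estimated at 110000 nM, between 50000 nM and 250000 nM. The step of an at least 1.3-fold lower number from compound 1 to compound 4 (0.13 log units; that floor lies within the scatter) is expected to be small and possibly unreadable.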

Compound 4, half-maximal inhibitory concentration: > 150000 nM
Compound 4 ended at the assay's limit; the forecaster's own chance of this, stated with the estimate: 40%; at least 1.3-fold (0.13 log units) between middle value and limit.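

In this assay, methyl in place of hydrogen on an aromatic carbon gives an at least 1.5-fold higher number from compound 3 to compound 4 (0.19 log units; that floor lies within the scatter), and since that floor lies within the scatter, the methyl cannot firmly be said to have made the compound weaker. Even so, compound 4 shows what compounds 1 and 2 could not: a substituent made of carbon alone, with no fluorine or bromine, also goes with a limit of the assay rather than a number, so among the four compounds shown only the unsubstituted phenyl of compound 3 gives a readable value. Compound 4 joins compounds 1 and 2 at one shared limit, the steps among these three cannot be read, and the series now stands at: the limit of > 150000 nM in this assay, at which 3 of the 4 values shown sit.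

The compounds shown leave open whether compounds 1, 2 and 4 differ from one another at all, so nothing can be said about how the three substituted phenyl groups rank. They also leave open whether an amine or a carboxylic acid on the phenyl, or a longer chain in place of it, would give a readable number in this assay.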